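Expected Solubility of Compound 4 From Three Limit Values

The source may hold more compounds than are shown below. What is called first, only, known or untested is meant among the compounds shown, and "the series" means these compounds.

Three analogues sharing one core have been measured in a physicochemical assay for solubility, read by spectrophotometry, in phosphate buffer, with a stated time of 2 h, at pH 7.4; a lower number here means a less soluble compound, a higher number a more soluble compound. Compound 1 `COc1ccc2[nH]c(C(=O)N3CC(=O)N(Cc4ccccc4)[C@@H](CN4CCCCC4)C3)cc2c1` reaches only a limit of the assay, > 25000 nM. Compound 2 `COc1ccc2[nH]c(C(=O)N3CC(=O)N(Cc4ccccc4)[C@@H](CCN4CCC5(CC4)CC5)C3)cc2c1` likewise stops at a limit, > 25000 nM. Compound 3 `COc1ccc2[nH]c(C(=O)N3CC(=O)N(Cc4ccccc4)[C@@H](Cc4ccccn4)C3)cc2c1` also gives a limit, > 100000 nM. Compound 3 therefore stands at the limit of > 100000 nM in this assay, at which 1 of the 3 values shown sits. The other two values sit at the limit of > 25000 nM in this assay, at which 2 of the 3 values shown sit. The steps a step that the two limits leave unreadable from compound 1 to compound 2, a step that the two limits leave unreadable from compound 1 to compound 3 and a step that the two limits leave unreadable from compound 2 to compound 3 cannot be sized; each joins two limits, so no direction can be read from any of them.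

Compound 4 `COc1ccc2[nH]c(C(=O)N3CC(=O)N(Cc4ccccc4)[C@@H](CN4CC5CC5C4)C3)cc2c1` has not yet been measured. It differs from compound 3 in one place: a group of 6 heavy atoms (5 carbon, 1 nitrogen; one three-membered non-aromatic ring of carbon only, one five-membered non-aromatic ring with 1 hetero atom) in place of a group of 6 heavy atoms (5 carbon, 1 nitrogen; one six-membered aromatic ring with 1 hetero atom), on a saturated chain carbon bound to a saturated ring carbon. The measured steps that bear on this change are the three at the same site, and none of them is readable, so they give neither a size nor a direction for the coming step. What they do show is that every variation at this position has so far left the compound at a limit of this assay. The step from compound 3 to compound 4 is therefore expected to be a number no higher from compound 3 to compound 4 (the limit leaves the size open), meaning no change beyond the scatter. Compound 4 is estimated at 100000 nM, with a range from 25000 nM to 300000 nM.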

Compound 4, solubility: 17500 nM
For compound 4 the middle estimate is 5.7-fold (0.76 log units) above the measured one, outside the stated range (below it).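

In this assay, for the compounds shown here, compound 4 gives 17500 nM, the only number rather than a limit among the four analogues, so this position can produce a readable value. Replacing pyridin-2-yl with the group bearing one three-membered non-aromatic ring of carbon only and one five-membered non-aromatic ring with 1 hetero atom gives an at least 5.7-fold lower number from compound 3 to compound 4 (0.75 log units; beyond the scatter), which shows that the read-out can move at a saturated chain carbon bound to a saturated ring carbon even when the counts of heavy atoms, donors and acceptors stay the same. The comparisons with the two saturated amine groups are weaker, as an at least 1.4-fold lower number from compound 2 to compound 4 (0.15 log units; that floor lies within the scatter) and an at least 1.4-fold lower number from compound 1 to compound 4 (0.15 log units; that floor lies within the scatter) each give only a floor that lies within the scatter, so neither establishes a real change.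

The steps among compound 1, compound 2 and compound 3 cannot be read, and compound 3 remains at a limit: the limit of > 100000 nM in this assay, at which 1 of the 4 values shown sits. As far as these compounds go, compound 1 and compound 2 also remain at a limit, and how a carboxylic acid or a plain alkyl chain at this place would read stays open: the limit of > 25000 nM in this assay, at which 2 of the 4 values shown sit.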